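This account rests on a few compounds, and the source may have more. Where it says the series, first, only, none or still open, it means among the compounds named here.

Measured compounds:
compound 1, `NS(=O)(=O)c1ccc(Nc2nc(N/N=C/c3ccc(C(F)(F)F)cc3)nc(Nc3ccccc3)n2)cc1`: 3000 nM
compound 2, `Cc1nn(-c2ccccc2)cc1/C=N/Nc1nc(Nc2ccccc2)nc(Nc2ccc(S(N)(=O)=O)cc2)n1`: 2940 nM

Both numbers come from a functional assay on SN12C cells (Homo sapiens) for inhibition, read by sulforhodamine B assay, with a stated time of 48 h; a lower number here means a stronger inhibitor of growth, a higher number a weaker inhibitor of growth. Compound 2 holds the lower of the two numbers, yet the step of a 1.0-fold lower number from compound 1 to compound 2 (0.01 log units; within the scatter) is within the scatter, so on these values nothing separates compound 2 from compound 1. The two share one core and differ only in the group attached to the carbon that carries a double bond to nitrogen.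

Compound 3, `NS(=O)(=O)c1ccc(Nc2nc(N/N=C/c3ccccn3)nc(Nc3ccccc3)n2)cc1`, changes that same position once more: pyridin-2-yl in place of 3-methyl-1-phenyl-1H-pyrazol-4-yl on a carbon with a double bond to nitrogen. Among the compounds with values here, the only measured step that bears on this change is a 1.0-fold lower number from compound 1 to compound 2 (0.01 log units; within the scatter), in which one aryl group was exchanged for another at the same carbon without any movement beyond the scatter. Within the data shown here, no measured step shows what pyridin-2-yl itself does here, so the expectation rests on that single comparison: a step of about the same small size, with no direction that can be called beyond the scatter. Compound 3 is therefore expected to give 3000 nM in this assay, with a range from 1000 nM to 9000 nM, a step of a 1.0-fold higher number from compound 2 to compound 3 (0.01 log units; within the scatter) that is expected to stay inside the scatter.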

Compound 3, concentration for 50% growth inhibition: 1010 nM
Beside the measured number, compound 3's estimate is 3.0-fold (0.47 log units) above it; measured number inside the range.
By their numbers in this assay, from the lowest: compound 3; then compounds 2 and 1 (each within the scatter of the next).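

Until now, the group on the carbon with a double bond to nitrogen seemed to matter little in this assay, but pyridin-2-yl moves the number beyond the scatter, with a 2.9-fold lower number from compound 2 to compound 3 (0.46 log units; beyond the scatter) and a 3.0-fold lower number from compound 1 to compound 3 (0.47 log units; beyond the scatter). Both steps are modest, yet they show that this position does respond to the group placed on it, and that a nitrogen in an aromatic ring is not enough on its own: 3-methyl-1-phenyl-1H-pyrazol-4-yl also has ring nitrogens, and compound 2 stays within the scatter of compound 1. No measurement offered here explains why pyridin-2-yl gives the lower number.

Pyridin-2-yl differs from 3-methyl-1-phenyl-1H-pyrazol-4-yl in both its ring and its size, so these compounds cannot say which difference counts. A plain phenyl, pyridin-3-yl or pyridin-4-yl on this carbon would help separate the effect of the ring nitrogen and its location, while an amine or a carboxylic acid on the pyridine ring would show how far this group can be changed.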